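Moving One Methyl Group Around a Phenyl Ring

A few compounds are considered here, and "the series" means these few. Any claim that something is new, unique, unknown or untested is made for them only; others in the source may bear on it.

In a functional assay on SGC-7901 cells (Homo sapiens) for inhibition, read by MTT assay, with a stated time of 24 h (a lower number here means a stronger inhibitor, a higher number a weaker inhibitor), compound 1 `CC1(C)[C@H]2CC[C@]1(C)N(Cc1cn(-c3ccc(C#N)cc3)nn1)C(=O)C2` gives 500 nM and compound 2 `Cc1ccccc1-n1cc(CN2C(=O)C[C@@H]3CC[C@@]2(C)C3(C)C)nn1` gives 350 nM. Going by the values given here, these two numbers lie within the scatter of each other, so compound 2 cannot be ranked against its only measured neighbour.

Compound 3 `Cc1cccc(-n2cc(CN3C(=O)C[C@@H]4CC[C@@]3(C)C4(C)C)nn2)c1` contains the same atoms as compound 2, joined differently, with 3-methylphenyl in place of 2-methylphenyl on an aromatic nitrogen. The rest of the molecule stays the same.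

Among the compounds with values here, only one measured step bears on this change, as it also swaps the group on that nitrogen. That step, with 2-methylphenyl in place of 4-cyanophenyl, is a 1.4-fold lower number from compound 1 to compound 2 (0.15 log units; within the scatter). Within the data shown here, it is small, and it is only a single step, so it offers a weak guide. Among the measured compounds shown here, no measured compound yet carries 3-methylphenyl.

On that evidence, no shift beyond the scatter is expected in this assay, and the expected step is a 1.1-fold higher number from compound 2 to compound 3 (0.06 log units; within the scatter). The estimate for compound 3 is 400 nM, with an expected range from 170 nM to 950 nM.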

Compound 3, half-maximal inhibitory concentration: 410 nM
For compound 3 the middle estimate is 1.0-fold (0.01 log units) below the measured one; the range from low to high includes it.
By their numbers in this assay, from the lowest: compounds 2, 3 and 1 (each within the scatter of the next).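

In this assay putting 3-methylphenyl in place of 2-methylphenyl on the aromatic nitrogen gives a 1.2-fold higher number from compound 2 to compound 3 (0.07 log units; within the scatter) and putting it in place of 4-cyanophenyl gives a 1.2-fold lower number from compound 1 to compound 3 (0.09 log units; within the scatter) and neither step stands clear of the usual scatter. This position has now carried three different substituted phenyl groups, and the three compounds cannot be told apart by their numbers: shifting the methyl group around the phenyl ring makes no difference that can be separated from the normal variation between repeated measurements, and neither does exchanging either methylphenyl group for 4-cyanophenyl. Nothing measured here offers an explanation for how closely these numbers sit together.

Going by these compounds, all three groups on this nitrogen are phenyl rings with one small substituent, so it remains open whether a phenyl ring bearing an amine or a carboxylic acid, or a longer alkyl chain in place of the ring, would move the number beyond the scatter. On these data alone, it also remains open whether this insensitivity to the methyl group's place holds anywhere outside this assay at all.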